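Sulfamoyl on the pyrazole-side phenyl: a new combination

The source may hold more compounds than are shown below. What is called first, only, known or untested is meant among the compounds shown, and "the series" means these compounds.

Measured compounds:
compound 1, `NS(=O)(=O)c1ccc(-n2nc(Nc3ccccc3)c3c(=O)n(-c4ccccc4)c(Nc4ccccc4)nc32)cc1`: 39.7%
compound 2, `O=c1c2c(Nc3ccc([N+](=O)[O-])cc3)nn(-c3ccccc3)c2nc(Nc2ccccc2)n1-c1ccccc1`: 15.1%

In a functional assay on the whole organism (strain Wistar albino) for inhibition, with Rattus norvegicus as the target, read by paw edema, with a stated time of 3 h, at a dose of 25 mg/kg by the oral route (a higher number here means more inhibition at the dose given (going by the name of the read-out), a lower number less inhibition), compound 1 gives 39.7%, while compound 2 gives 15.1%, the lowest of the two numbers and a gap to compound 1 that lies beyond the scatter. Within the data shown here, the two compounds differ in more than one place, so no single step between them is drawn; their values show only that compound 1 stands clearly higher in this assay.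

Compound 3, `NS(=O)(=O)c1ccc(-n2nc(Nc3ccc([N+](=O)[O-])cc3)c3c(=O)n(-c4ccccc4)c(Nc4ccccc4)nc32)cc1`, has not yet been measured. It differs from compound 2 in one place: sulfamoyl in place of hydrogen on an aromatic carbon. Compound 1, which also carries the sulfamoyl group, shows the higher number of the two, so compound 3 is expected to sit above compound 2 in this assay, with a step of a number 11.9 percentage points higher from compound 2 to compound 3 (beyond the scatter) that may just clear the scatter. The estimate for compound 3 is 27%, with a range from 14% to 42%.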

Compound 3, a percentage reported as inhibition, in the whole organism at one dose (the size of the read-out at that dose, not a potency): 39.1%
For compound 3 the middle estimate is 12.1 percentage points below the measured one; the measured number falls inside the stated range.
By their numbers in this assay, from the lowest: compound 2; then compounds 3 and 1 (each within the scatter of the next).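

In this assay, the change from phenyl to 4-sulfamoylphenyl gives a number 24 percentage points higher from compound 2 to compound 3 (beyond the scatter) in a single place, so the sulfamoyl group at this position is now tied directly to higher inhibition on the nitro-bearing scaffold, something the earlier pair, which differed in more than one place, could not show. With sulfamoyl already present, nitro in place of hydrogen gives a number 0.6 percentage points lower from compound 1 to compound 3 (within the scatter) and so leaves the read-out within the scatter. No measurement at hand explains either step.

Whether the sulfamoyl step also holds on the scaffold without the nitro group remains open, since no pair shown reads that change. Going by these compounds, it is equally open whether a carboxylic acid or an amine at this position on the phenyl ring would match sulfamoyl in this assay at this dose.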